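A Swap on the Chain of Compound 2

This account rests on a few compounds, and the source may have more. Where it says the series, first, only, none or still open, it means among the compounds named here.

Of the compounds shown here, three built on a shared core have been tested in a functional assay on the whole organism with Rattus norvegicus as the target; a lower number here means that less compound is needed, a higher number that more compound is needed for the effect. Compound 1 `CC/N=C(/NC#N)NCCCCCn1nc(-c2ccccc2)ccc1=O` gives 60.3 mg/kg. Compound 2 `C/N=C(\S)NCCCn1nc(-c2ccccc2)ccc1=O` gives 58 mg/kg, and compound 3 `NC(=O)SCCCCCN1NC=CC=C1c1ccccc1` gives 18.3 mg/kg. Among these three numbers compound 2 stands second highest; the number of compound 1 sits within the scatter of it, so the two cannot be told apart, whereas the number of compound 3 lies beyond the scatter below it.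

Compound 4 `CN(C)/C(=N/CCCn1nc(-c2ccccc2)ccc1=O)NC#N` has not yet been measured. It differs from compound 2 in one place: a group of 8 heavy atoms (4 carbon, 4 nitrogen; no ring) in place of a group of 5 heavy atoms (2 carbon, 2 nitrogen, 1 sulfur; no ring), on a saturated chain carbon, three bonds along the chain from an aromatic nitrogen. Going by the values given here, no pair of measured compounds differs in one place only, so no directly comparable step is at hand. Compound 1 also carries on its chain a group with a triple bond outside aromatic rings, and it gives 60.3 mg/kg, within the scatter of compound 2, which suggests that this kind of group does not move the number much. The change is therefore expected to bring a step of a 1.1-fold lower number from compound 2 to compound 4 (0.02 log units; within the scatter), which is no change beyond the scatter. For compound 4 in this assay the expected value is 55 mg/kg, with a likely range from 25 mg/kg to 120 mg/kg.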

Compound 4, dose for half-maximal effect: 93.1 mg/kg
For compound 4 the middle estimate is 1.7-fold (0.23 log units) below the measured one, within the range that was stated.
By their numbers in this assay, from the lowest: compound 3; then compounds 2, 1 and 4 (each within the scatter of the next).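

Going by these compounds alone, this is the first comparison in the set in which only one place differs. In this assay the swap brings a 1.6-fold higher number from compound 2 to compound 4 (0.21 log units; within the scatter), so compound 2 and compound 4 cannot be told apart, even though the group of 8 heavy atoms is larger, holds a triple bond as well as a double bond, and has no sulfur, and the count of hydrogen-bond donors and acceptors differs too. At this place on the saturated chain, then, a quite different group leaves the dose needed in the whole animal within the usual scatter of repeat measurements, although this single pair cannot show how far that holds, and nothing available here offers an explanation for the result.

As far as these compounds go, it remains open whether a simple amine or a carboxylic acid at the same place on the chain would also stay within the scatter, or would shift the number clearly. Compound 3 differs from the others in more than one place, so the compounds shown cannot tell which of its features goes with its separate number.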